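From furan-2-yl to 4-methoxyphenyl: estimating a half-life

A few compounds are considered here, and "the series" means these few. Any claim that something is new, unique, unknown or untested is made for them only; others in the source may bear on it.

Three compounds measured in an ADME assay on cells (Hepatocyte, Mus musculus) for metabolic stability (on this read-out lower numbers stand for a shorter-lived compound and higher numbers for a longer-lived compound), gave these results
Compound 1 `O=C(OC1CCC(CN2CCN(c3cc(=O)c4cc(C(F)(F)F)cc([N+](=O)[O-])c4s3)CC2)CC1)c1ccncc1` gives 0.0817 h
Compound 2 `Cc1ccc(C(=O)OC2CCC(CN3CCN(c4cc(=O)c5cc(C(F)(F)F)cc([N+](=O)[O-])c5s4)CC3)CC2)cc1` gives 0.202 h
Compound 3 `O=C(OC1CCC(CN2CCN(c3cc(=O)c4cc(C(F)(F)F)cc([N+](=O)[O-])c4s3)CC2)CC1)c1ccco1` gives < 0.075 h (a limit, not a number)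

Compound 3 has only a limit and no number in this assay (the limit of < 0.075 h in this assay, at which 1 of the 3 values shown sits). Compound 4 `COc1ccc(C(=O)OC2CCC(CN3CCN(c4cc(=O)c5cc(C(F)(F)F)cc([N+](=O)[O-])c5s4)CC3)CC2)cc1` has not yet been measured. It carries 4-methoxyphenyl in place of furan-2-yl on a carbonyl carbon.

Among the measured compounds, the closest guide is compound 2, whose 4-methylphenyl group sits at the same place and most resembles the incoming 4-methoxyphenyl. Putting furan-2-yl in place of that group gave a drop beyond the scatter (an at least 2.6-fold lower number from compound 2 to compound 3 (0.43 log units; beyond the scatter)), and the change to compound 4 runs roughly the opposite way. The step between the pyridin-4-yl and 4-methylphenyl compounds was modest and also beyond the scatter (a 2.5-fold higher number from compound 1 to compound 2 (0.39 log units; beyond the scatter)). The step between the pyridin-4-yl and furan-2-yl compounds says little, as its floor lies within the scatter (an at least 1.0-fold lower number from compound 1 to compound 3 (0.03 log units; that floor lies within the scatter)).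

A modest rise is therefore expected, bringing compound 4 near compound 2. The estimated step is an increase (an at least 2.1-fold higher number from compound 3 to compound 4 (0.32 log units; beyond the scatter)). The estimated half-life for compound 4 is 0.16 h (expected range 0.08 h to 0.33 h).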

Compound 4, half-life: 0.295 h
Estimate against measurement, compound 4: 1.8-fold (0.27 log units) below; measured number inside the range.
By their numbers in this assay, from the lowest: compound 1; then compounds 2 and 4 (each within the scatter of the next). At a limit, below all of these: compound 3.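

The step from furan-2-yl to 4-methoxyphenyl on this carbonyl carbon can be read in this assay, at least as a minimum: an at least 3.9-fold higher number from compound 3 to compound 4 (0.59 log units; beyond the scatter). Compound 3 has only a limit, so this step is a floor and its full size cannot be told: the limit of < 0.075 h in this assay, at which 1 of the 4 values shown sits. Methoxy in place of methyl on the aromatic carbon gives a 1.5-fold higher number from compound 2 to compound 4 (0.16 log units; within the scatter), so these two groups cannot be told apart here, whereas 4-methoxyphenyl in place of pyridin-4-yl gives a 3.6-fold higher number from compound 1 to compound 4 (0.56 log units; beyond the scatter), which places both groups on a carbon-only aromatic ring clear of the pyridin-4-yl and furan-2-yl groups.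

Going by these compounds, it remains open whether the carbon-only aromatic ring alone is enough, or whether the group it carries also matters, as a plain phenyl group would show. Also open, on these data alone, is how this half-life would respond to a phenyl group carrying an amine or a carboxylic acid in place of the methoxy, or to a saturated ring such as cyclohexyl on the carbonyl carbon.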